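The source may report more compounds than this note shows. Statements on the series, on what has been measured and on what is new or still open speak of the compounds shown alone.

Compound 1 `N#CC1=C(N)Oc2c(c3nc4ccccc4nc3c3ccccc23)C12C(=O)N(Cc1cnnn1-c1ccccc1Br)c1ccccc12`: in a functional assay on HepG2 cells (Homo sapiens) for antiproliferative activity, read by MTT assay, with a stated time of 48 h (a higher number here means a weaker inhibitor, a lower number a stronger inhibitor), compound 1 gives > 50000 nM, which is a limit of the assay.
Compound 2 `Cc1ccc(Cl)cc1-n1nncc1CN1C(=O)C2(C(C#N)=C(N)Oc3c2c2nc4ccccc4nc2c2ccccc32)c2ccccc21`: compound 2 gives > 50000 nM, also a limit.
Compound 3 `N#CC1=C(N)Oc2c(N)cc3nc4ccccc4nc3c2C12C(=O)N(Cc1cnnn1-c1ccccc1Br)c1ccccc12`: compound 3 gives 38000 nM.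

For the measured compounds named here, compound 3 thus stands as the only compound with a number; the other two sit at the limit of > 50000 nM in this assay, at which 2 of the 3 values shown sit. Going by the values given here, the single measured step, a step that the two limits leave unreadable from compound 1 to compound 2, runs between two limits and its size cannot be read, so no measured step informs the change at hand. Compound 4 `N#CC1=C(N)Oc2c(N)cc3nc4ccccc4nc3c2C12C(=O)N(Cc1cnnn1-c1ccc([N+](=O)[O-])cc1[N+](=O)[O-])c1ccccc12` differs from compound 3 as 2,4-dinitrophenyl in place of 2-bromophenyl on an aromatic nitrogen. With nothing readable to draw on, the expectation is a step from compound 3 to compound 4 of no change at the digits printed from compound 3 to compound 4 (within the scatter), not beyond the scatter. For compound 4 the estimate in this assay is 38000 nM, between 12000 nM and 120000 nM.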

Compound 4, half-maximal inhibitory concentration: 18400 nM
Compound 4: middle estimate off by 2.1-fold (0.31 log units), on the high side; the measured number falls inside the stated range.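

In this assay, for the compounds shown here, the change to 2,4-dinitrophenyl gives a 2.1-fold lower number from compound 3 to compound 4 (0.31 log units; beyond the scatter) as the first readable step on this aromatic nitrogen, since the earlier step between compound 1 and compound 2 cannot be read. The group on this nitrogen can therefore move the number modestly when the shared core carries the amine of compound 3. Much of the series still rests at a limit, not at a number: the limit of > 50000 nM in this assay, at which 2 of the 4 values shown sit.

From the compounds shown here alone, whether a single nitro group on that phenyl ring gives the same step remains open. So does whether an amine there would.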